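The source may report more compounds than this note shows. Statements on the series, on what has been measured and on what is new or still open speak of the compounds shown alone.

In a functional assay on HCT-116 cells (Homo sapiens) for antiproliferative activity, read by MTT assay, with a stated time of 48 h (a higher number here means a weaker inhibitor, a lower number a stronger inhibitor), compound 1, with the structure `CCCCCCC(CCO)n1cnc2c(Cl)ncnc21`, gives 11900 nM. Compound 2, with the structure `CCCCCCC(CCO)n1cnc2c(OC)ncnc21`, gives only a limit of the assay, > 50000 nM, so its true number is not known. Compound 2 differs from compound 1 by methoxy in place of chloro on an aromatic carbon, and that change brought an at least 4.2-fold higher number from compound 1 to compound 2 (0.62 log units; beyond the scatter), a step shaped by the limit (the limit of > 50000 nM in this assay, at which 1 of the 3 values shown sits).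

Compound 3, with the structure `CCCCCCCCCCCC(CCO)n1cnc2c(Cl)ncnc21`, differs from compound 1 by pentyl in place of hydrogen on a saturated chain carbon, seven bonds along the chain from an aromatic nitrogen. In this assay compound 3 gives 7590 nM, which is a 1.6-fold lower number from compound 1 to compound 3 (0.20 log units; within the scatter), so the two cores behave alike here.

Compound 4, with the structure `CCCCCCCCCCCC(CCO)n1cnc2c(OC)ncnc21`, has not yet been measured. Going by the values given here, it differs from compound 3 by methoxy in place of chloro on an aromatic carbon, the same change as the one from compound 1 to compound 2, at the same place on the shared core. Since compound 3 sits close to compound 1, as the step of a 1.6-fold lower number from compound 1 to compound 3 (0.20 log units; within the scatter) shows, compound 4 is expected to move roughly as compound 2 did, giving an expected 6.6-fold higher number from compound 3 to compound 4 (0.82 log units; beyond the scatter). The estimate for compound 4 is therefore 50000 nM, most likely between 20000 nM and 150000 nM, with a fair chance that only a limit is reported.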

Compound 4, half-maximal inhibitory concentration: 8230 nM
The estimate for compound 4 lay 6.1-fold (0.78 log units) above the measured number; the measured number lies below the stated range.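

On the core carrying the added pentyl, methoxy in place of chloro brought a 1.1-fold higher number from compound 3 to compound 4 (0.04 log units; within the scatter) in this assay, so the loss seen on the core of compound 1 did not carry over to this second core: the same change on two cores in this assay, an at least 4.2-fold higher number (0.62 log units; beyond the scatter) from compound 1 to compound 2 and a 1.1-fold higher number (0.04 log units; within the scatter) from compound 3 to compound 4, at least 3.8-fold (0.58 log units) apart, beyond the scatter of two such steps

Read the other way, adding pentyl gave an at least 6.0-fold lower number from compound 2 to compound 4 (0.78 log units; beyond the scatter), a clear step with methoxy on the shared core, whereas with chloro the same addition stayed within the scatter: the same change on two cores in this assay, a 1.6-fold lower number (0.20 log units; within the scatter) from compound 1 to compound 3 and an at least 6.0-fold lower number (0.78 log units; beyond the scatter) from compound 2 to compound 4, at least 3.8-fold (0.58 log units) apart, beyond the scatter of two such steps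

Compound 2 gives only a limit, so the true size of each step that touches it is unknown, and a comparison of just two cores gives neither a reason for the difference nor a rule for the series: the limit of > 50000 nM in this assay, at which 1 of the 4 values shown sits.

The compounds shown leave open how an amine in place of the chloro or methoxy would behave on these two cores. They also leave open whether a still longer chain would keep methoxy and chloro as close as they are in compound 3 and compound 4.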